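This account rests on a few compounds, and the source may have more. Where it says the series, first, only, none or still open, it means among the compounds named here.

Measured compounds:
- compound 1, `COc1ccccc1/C=N/NC(=O)c1ccc(-c2ccc(F)cc2F)o1`, gives 53.1%
- compound 2, `O=C(N/N=C/c1ccc(-c2cccc(F)c2)o1)c1ccc(Br)cc1`, gives 28.2%
- compound 3, `O=C(N/N=C/c1ccc(O)cc1)c1ccc(-c2ccc(F)cc2)o1`, gives 10.6%

All three were tested in a functional assay on Bel-7402 cells (Homo sapiens) for inhibition, read by sulforhodamine B assay, with a stated time of 48 h, tested at 10 uM; a higher number here means more inhibition of growth at the concentration tested, a lower number less inhibition of growth. Among them compound 1 stands highest: its number sits well above that of compound 2, and further still above that of compound 3, and both gaps lie beyond the usual scatter of repeated measurements. Compound 3, which carries a hydroxy group on its terminal phenyl ring, gives the lowest number of the three.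

The next compound, compound 4, `O=C(N/N=C/c1ccccc1O)c1ccc(-c2ccc(F)cc2F)o1`, keeps the core of compound 1 and changes only one spot. The change from compound 1 to compound 4 is hydrogen in place of methyl on an oxygen on an aromatic ring; cut one bond further out it reads methoxy to hydroxy, or 2-methoxyphenyl to 2-hydroxyphenyl.

For the measured compounds named here, no pair of measured compounds differs in just one place, so the size of such a step cannot be read directly from the numbers. Going by the values given here, the only measured compound with a hydroxyphenyl group, compound 3, gives the low value 10.6%, but it also differs from compound 1 elsewhere. A small to moderate drop is therefore expected, though one that may fall within the scatter; the expected step is a number 13.1 percentage points lower from compound 1 to compound 4 (beyond the scatter). For compound 4 the estimate is 40%, with a range from 15% to 65%.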

Compound 4, percent growth inhibition at one concentration: 91.8%
Compound 4: middle estimate off by 51.8 percentage points, on the low side, outside the stated range (above it).
By their numbers in this assay, from the lowest: compound 3; then compound 2; then compound 1; then compound 4.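

In this assay, the swap of methoxy for hydroxy, which puts hydrogen in place of methyl on an oxygen on an aromatic ring, gives a number 38.7 percentage points higher from compound 1 to compound 4 (beyond the scatter), a large step. For the compounds shown here, this is the first comparison here in which only one place differs, and it shows that this single oxygen substituent strongly affects growth inhibition even though the change removes only one heavy atom, a carbon, while the rest of the core of compound 1 stays the same. Nothing available here explains why the number rises with this change.

From the compounds shown here alone, it remains open whether other groups in the same place, such as an amine, a carboxylic acid or a longer chain like ethoxy, would give numbers closer to compound 1 or to compound 4, and so whether the hydroxy group itself is special or the methoxy group is simply a poor fit for this result. Going by these compounds, it is also open whether the same swap would produce a step of similar size on a compound with a different terminal ring, since this single pair cannot establish a wider pattern.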